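The source may report more compounds than this note shows. Statements on the series, on what has been measured and on what is new or still open speak of the compounds shown alone.

Compound 3 `CCNC(=O)Nc1nc2cc(-c3cnc(N4CCCC4(C)C(=O)O)nc3)cc(-c3ccccn3)c2s1` stands at the upper edge of what can be read here: in a physicochemical assay for solubility, read by turbidimetry, in phosphate buffer, with a stated time of 24 h, at pH 7.4 (a higher number here means a more soluble compound, a lower number a less soluble compound), compound 3 gives > 800 ug/mL, which is a limit of the assay and not a number. Compound 1 `CCNC(=O)Nc1nc2cc(-c3cnc(N4CCC(C)(C(=O)O)CC4)nc3)cc(-c3ccccn3)c2s1` also gives > 800 ug/mL in this assay, again a limit. Compound 2 `CCNC(=O)Nc1nc2cc(-c3cnc(N4CCC(N)(C(=O)O)CC4)nc3)cc(-c3ccccn3)c2s1` gives 25 ug/mL in this assay. The step of an at least 32-fold higher number from compound 2 to compound 3 (1.50 log units; beyond the scatter) is large, whereas a step that the two limits leave unreadable from compound 1 to compound 3 cannot be read since both ends sit at the limit of > 800 ug/mL in this assay, at which 2 of the 3 values shown sit. The change leading to compound 4 `CCNC(=O)Nc1nc2cc(-c3cnc(N4CCCCC4(C)C(=O)O)nc3)cc(-c3ccccn3)c2s1` is 2-carboxy-2-methylpiperidin-1-yl in place of 2-carboxy-2-methylpyrrolidin-1-yl on an aromatic carbon. Compound 1 carries the same carboxy and methyl on a six-membered non-aromatic ring and sits at that limit. On that basis the expected step is a number no higher from compound 3 to compound 4 (the limit leaves the size open), nothing beyond the scatter. Compound 4 is estimated at 800 ug/mL, between 300 ug/mL and 1600 ug/mL, most probably reported once more as a limit.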

Compound 4, solubility: 6.25 ug/mL
Estimate against measurement, compound 4: 130-fold (2.11 log units) above; measured number below the stated range.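

At this position, one added ring carbon with carboxy and methyl kept gives an at least 120-fold lower number from compound 3 to compound 4 (2.10 log units; beyond the scatter) in this assay, and the same groups placed differently on a six-membered ring give an at least 120-fold lower number from compound 1 to compound 4 (2.10 log units; beyond the scatter). Both steps start from a limit of the assay, not a number: the limit of > 800 ug/mL in this assay, at which 2 of the 4 values shown sit. The remaining comparison, with the amino-bearing ring, gives a 4.0-fold lower number from compound 2 to compound 4 (0.60 log units; beyond the scatter), so the result depends on more than ring size alone.

Still open, from the compounds shown here alone, is whether 2-carboxypiperidin-1-yl without the methyl, or a seven-membered ring carrying carboxy and methyl, would stay near compound 4 or rise again.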